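The compounds below may be only part of what the source reports. "The series", "measured", "known", "first", "only" and "open" are said of these compounds alone.

Working notes on the series. The three measured compounds share one core and differ in the linker and in the iodo group. Compound 1 `O=C1C(=O)N(CCCCCn2cc(COc3cc(=O)oc4ccccc34)nn2)c2ccc(I)cc21` gives 36% in a functional assay on HCT-116 cells (Homo sapiens) for inhibition, read by sulforhodamine B assay, with a stated time of 48 h, tested at 50 uM (a higher number here means more inhibition of growth at the concentration tested, a lower number less inhibition of growth), the lowest of the three values. Compound 2 `O=C1C(=O)N(CCCn2cc(COc3cc(=O)oc4ccccc34)nn2)c2ccccc21` gives 79% in this assay, and compound 3 `O=C1C(=O)N(CCCn2cc(COc3cc(=O)oc4ccccc34)nn2)c2ccc(I)cc21` gives 65%. For the measured compounds named here, the one counted step is a number 14 percentage points higher from compound 3 to compound 2 (beyond the scatter), the change being (hydrogen in place of iodo on an aromatic carbon). How the core of compound 1 differs from that of compound 3 is not broken down here.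

Compound 4 `O=C1C(=O)N(CCCCCn2cc(COc3cc(=O)oc4ccccc34)nn2)c2ccccc21` is not yet measured. It differs from compound 1 by hydrogen in place of iodo on an aromatic carbon, the same change as from compound 3 to compound 2. Because a number 14 percentage points higher from compound 3 to compound 2 (beyond the scatter) was modest, a similar step a number 14 percentage points higher from compound 1 to compound 4 (beyond the scatter) is expected, resting on one precedent only. Compound 4 is therefore estimated at 50%, with a range of 35% to 65%.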

Compound 4, percent growth inhibition at one concentration: 65%
For compound 4 the middle estimate is 15 percentage points below the measured one; measured number inside the range.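

Hydrogen in place of iodo gives a number 29 percentage points higher from compound 1 to compound 4 (beyond the scatter) in this assay. The direction of the change is the same on both cores, but its size does not carry over from one core to the other: the same change on two cores in this assay, a number 14 percentage points higher (beyond the scatter) from compound 3 to compound 2 and a number 29 percentage points higher (beyond the scatter) from compound 1 to compound 4, 15 percentage points apart, beyond the scatter of two such steps. Two cores give no rule for predicting the size of the step on a further core, and these values do not show why the two steps differ.

Still open, as far as these compounds go, is how a smaller halogen such as chloro or bromo, or a methoxy group, on the same aromatic carbon compares with iodo and hydrogen. Also open, from the compounds shown here alone, is whether the step changes again on a core with a chain longer than that of compound 1.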